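The source may hold more compounds than are shown below. What is called first, only, known or untested is meant among the compounds shown, and "the series" means these compounds.

Of the compounds shown here, three have so far been measured in a toxicity assay on WI-38 cells (Homo sapiens) for inhibition, read by MTT assay, with a stated time of 48 h (on this read-out higher numbers stand for weaker inhibition and lower numbers for stronger inhibition), and their numbers sit close together. Compound 1 `Cc1c(NC(=O)NCCN2C(=O)S/C(=C\c3ccc([N+](=O)[O-])cc3)C2=O)c(=O)n(-c2ccccc2)n1C` reads 76400 nM while compound 2 `COc1cc(/C=C2\SC(=O)N(CCNC(=O)Nc3c(C)n(C)n(-c4ccccc4)c3=O)C2=O)cc(OC)c1OC` reads 51500 nM and compound 3 `Cc1ccc(/C=C2\SC(=O)N(CC(=O)Nc3c(C)n(C)n(-c4ccccc4)c3=O)C2=O)cc1` reads 83700 nM on this scale. Compound 3 therefore lies within the usual scatter of both others, and no order can be drawn among the three.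

Compound 4 `Cc1c(NC(=O)CN2C(=O)S/C(=C\c3ccc(Br)cc3)C2=O)c(=O)n(-c2ccccc2)n1C` alters compound 3 in one place only: bromo in place of methyl on an aromatic carbon and in words this is bromo in place of methyl on an aromatic carbon, so that 4-methylphenyl becomes 4-bromophenyl. Among the measured compounds shown here, no measured pair shows this exact swap. The nearest evidence is the exchange of 4-nitrophenyl for 3,4,5-trimethoxyphenyl, which gave a 1.5-fold lower number from compound 1 to compound 2 (0.17 log units; within the scatter) and so stayed inside the scatter. Compounds 1 and 2 also carry a different chain from compound 3, which makes this guidance indirect.

With that single small step and three closely grouped values, no step beyond the scatter is expected in this assay in either direction. The estimated change is a 1.1-fold lower number from compound 3 to compound 4 (0.05 log units; within the scatter) and it would stay within the scatter. The expected value for compound 4 is 75000 nM with an estimated range from 40000 nM to 130000 nM for a single measurement.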

Compound 4, half-maximal inhibitory concentration: 66700 nM
Compound 4: the middle estimate sits 1.1-fold (0.05 log units) above what was measured; the measured number falls inside the stated range.
By their numbers in this assay, from the lowest: compounds 2, 4, 1 and 3 (each within the scatter of the next).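

In this assay, putting bromo in place of methyl gives a 1.3-fold lower number from compound 3 to compound 4 (0.10 log units; within the scatter) and is the first step among these compounds that reads a single-atom exchange at this position, on an aromatic carbon para to a large group. The earlier step changed one whole substituted phenyl for another on the chain of compound 1, whereas this one keeps the chain of compound 3 and shows that going from 4-methylphenyl to 4-bromophenyl leaves the number inside the usual scatter. No measurement at hand accounts for this result or tells what either group does here.

Going by these compounds, what remains open is whether this position stays so flat when it carries a very different kind of group, such as an amine or a carboxylic acid, since all four compounds sit close together and none of them shows a step beyond the scatter. On these data alone, it is also open whether the same exchange of methyl for bromo would read alike on the chain that compound 1 and compound 2 carry.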